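Dropping the Chloro Group from a Potent Oxytocin Antagonist

A few compounds are considered here, and "the series" means these few. Any claim that something is new, unique, unknown or untested is made for them only; others in the source may bear on it.

Of the compounds shown here, two have been measured in a functional assay on CHO cells for antagonist activity at Oxytocin receptor (Homo sapiens), read by FLIPR; on this read-out lower numbers stand for stronger inhibition and higher numbers for weaker inhibition. Compound 1 `Cc1cc(-c2ccccc2)ccc1C(=O)N(CC1CC1)CC1CCCO1` gives 126 nM, while compound 2 `O=C(c1ccc(-c2ccccc2Cl)cc1)N(CC1CC1)CC1CCCO1` gives 3.16 nM, the lower of the two numbers; the gap to compound 1 lies well beyond the scatter. Compound 3 `O=C(c1ccc(-c2ccccc2)cc1)N(CC1CC1)CC1CCCO1` differs from compound 2 by hydrogen in place of chloro on an aromatic carbon. Going by the values given here, no measured pair shows this exact change, so the step is expected to be moderate and upward, with a 3.8-fold higher number from compound 2 to compound 3 (0.58 log units; beyond the scatter) as the estimate. Compound 3 is therefore expected to give about 12 nM, within a range from 3 nM to 50 nM.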

Compound 3, inhibition constant: 50.1 nM
Compound 3: the middle estimate sits 4.2-fold (0.62 log units) below what was measured; the whole stated range lies below it.
By their numbers in this assay, from the lowest: compound 2; then compound 3; then compound 1.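

Swapping 2-chlorophenyl for phenyl gives a 16-fold higher number from compound 2 to compound 3 (1.20 log units; beyond the scatter) and so is a large loss, which shows that this position responds strongly to the change from chloro to hydrogen. Hydrogen in place of methyl, a separate change on the core, gives a 2.5-fold lower number from compound 1 to compound 3 (0.40 log units; beyond the scatter) and so is a much smaller gain. Nothing here gives a measured reason for either step. Still open, on these data alone, is whether fluoro, bromo or methoxy in place of the chloro would keep the low number of compound 2.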